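The source may hold more compounds than are shown below. What is called first, only, known or untested is meant among the compounds shown, and "the series" means these compounds.

Measured so far:
Compound 1 `Cc1nc(N2CCC(N3CCCS3(=O)=O)CC2)nc2ccc(NC(=O)/C=C/c3ccc(OC(F)(F)F)cc3)cc12`: 16 nM
Compound 2 `CCCC1(O)CCN(c2nc(C)c3cc(NC(=O)/C=C/c4ccc(Cl)cc4)ccc3n2)CC1`: 91 nM

Of the compounds shown here, two have been tested in a functional assay on CHO-K1 cells for antagonist activity at melanin-concentrating hormone receptor 1 (Homo sapiens), read by inositol phosphate accumulation, with stated times of 10 min and 45 min; a lower number here means a stronger inhibitor, a higher number a weaker inhibitor. Compound 1 gives 16 nM and is the lower of the two numbers; compound 2 gives 91 nM, a higher number than compound 1 by a margin that lies beyond the usual scatter of repeated runs. Since compound 2 differs from compound 1 in more than one place, the gap between them cannot be assigned to any single change.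

Compound 3 `Cc1nc(N2CCC(N3CCCC3=O)CC2)nc2ccc(NC(=O)/C=C/c3ccc(OC(F)(F)F)cc3)cc12` has not been measured. It keeps the core of compound 1 and differs from it in one place: a group of 6 heavy atoms (4 carbon, 1 nitrogen, 1 oxygen; one five-membered non-aromatic ring with 1 hetero atom) in place of a group of 7 heavy atoms (3 carbon, 1 nitrogen, 2 oxygen, 1 sulfur; one five-membered non-aromatic ring with 2 hetero atoms), on a saturated ring carbon. Within the data shown here, no measured pair shows a step of this kind, so the expected size of the step in this assay rests only on the general similarity of the two five-membered groups. The replacement removes one of the two hydrogen-bond acceptors counted for the leaving group, and a small rise in the number is thought most likely, not clearly beyond the scatter. The step of a 1.6-fold higher number from compound 1 to compound 3 (0.19 log units; within the scatter) is the expected outcome. Compound 3 is expected to give 25 nM, most likely between 8 nM and 80 nM.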

Compound 3, half-maximal inhibitory concentration: 12 nM
Beside the measured number, compound 3's estimate is 2.1-fold (0.32 log units) above it; the measured number falls inside the stated range.
By their numbers in this assay, from the lowest: compounds 3 and 1 (each within the scatter of the next); then compound 2.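

In this assay, putting 2-oxopyrrolidin-1-yl in place of the sulfur-bearing five-membered ring gives a 1.3-fold lower number from compound 1 to compound 3 (0.12 log units; within the scatter), so the two compounds cannot be told apart at this position, on a saturated ring carbon of the six-membered ring with 1 nitrogen. The earlier compounds shown here could not show this, as they differ in more than one place; this pair shows that, on this core, the sulfur atom can leave and the hydrogen-bond acceptor count of the group can fall with no change that stands clear of the scatter. No measurement here explains why the two groups read alike.

Going by these compounds, it remains open whether the carbonyl group of the lactam or the ring itself is needed here, which a plain pyrrolidin-1-yl amine or an open-chain acetamide at the same ring carbon would address. Also open, on these data alone, is whether the two groups would still read alike if the trifluoromethoxy group elsewhere in the molecule gave way to a chlorine atom.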